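Removing the fluoro group from compound 1

This account rests on a few compounds, and the source may have more. Where it says the series, first, only, none or still open, it means among the compounds named here.

Measured so far in a functional assay on NCI-H460 cells (Homo sapiens) for inhibition, read by sulforhodamine B assay, with a stated time of 72 h (a higher number here means a weaker inhibitor of growth, a lower number a stronger inhibitor of growth), two compounds:
- compound 1 `O=S(=O)(Nc1cc(-c2cnc3[nH]cc(-c4ccncc4)c3c2)cnc1Cl)c1ccccc1F`: > 10000 nM (a limit, not a number)
- compound 2 `O=S(=O)(Nc1cc(-c2cnc3[nH]ncc3c2)cnc1Cl)c1ccccc1`: 7610 nM (a number)

Compound 1 stands at the limit of > 10000 nM in this assay, at which 1 of the 2 values shown sits, so its position is known only as a limit.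

Compound 3 `O=S(=O)(Nc1cc(-c2cnc3[nH]cc(-c4ccncc4)c3c2)cnc1Cl)c1ccccc1` is compound 1 with hydrogen in place of fluoro on an aromatic carbon, ortho to a large group, the change from 2-fluorophenyl to phenyl (hydrogen in place of fluoro on an aromatic carbon). Within the data shown here, no measured pair isolates this change. In this assay no step beyond the usual scatter is expected, and no direction can be favoured. Compound 2 also carries phenylsulfonyl and gives 7610 nM on a different core, which gives no ground to expect strong growth inhibition. The estimated change is a number no higher from compound 1 to compound 3 (the limit leaves the size open) in size. Compound 3 is expected at 10000 nM, within an estimated range of 4000 nM to 25000 nM, and may well also read as a limit.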

Compound 3, concentration for 50% growth inhibition: 3900 nM
Estimate against measurement, compound 3: 2.6-fold (0.41 log units) above, outside the stated range (below it).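

In this assay, hydrogen in place of fluoro on the aromatic carbon ortho to a large group gives an at least 2.5-fold lower number from compound 1 to compound 3 (0.40 log units; beyond the scatter). Among these compounds, no earlier pair isolated this place, and on the core of compound 1 the step shows that this carbon is not indifferent to which of the two atoms it carries. The full size of the step stays unknown, and compound 1 enters it only as a limit: the limit of > 10000 nM in this assay, at which 1 of the 3 values shown sits.

As far as these compounds go, whether other groups at this carbon, such as methoxy or an amine, would give a lower or a higher number than hydrogen remains open. Also open, from the compounds shown here alone, is whether the step from 2-fluorophenyl to phenyl would carry over to the core of compound 2.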